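This account rests on a few compounds, and the source may have more. Where it says the series, first, only, none or still open, it means among the compounds named here.

Working notes on the series, read in an ADME assay on CCRF-CEM cells (Homo sapiens) for cytotoxicity, with a stated time of 3 days; a lower number here means that less compound is tolerated, a higher number that more compound is tolerated. Compound 1 `Cc1ccc(Cn2c(=O)ccn(C3C=CC(OC(=O)c4ccccc4)C3)c2=O)cc1` is reported at > 25000 nM, and this is a limit, not a number. Compound 2 `O=C(OC1C=CC(n2ccc(=O)n(C(=O)c3ccccc3)c2=O)C1)c1ccccc1` is reported at >= 250000 nM, and this too is a limit. Compound 2 therefore has no exact place in the series, and no measured number exists yet to set it against.

The next change leads to compound 3 `O=C(OC1C=CC(n2ccc(=O)[nH]c2=O)C1)c1ccccc1`: hydrogen in place of benzoyl on an aromatic nitrogen. In words, this is hydrogen in place of benzoyl on an aromatic nitrogen. Benzoyl is the group that entered in the only measured step, a step that the two limits leave unreadable from compound 1 to compound 2. That step bears on the change, but it gives neither a size nor a direction, so any expectation here is weak. With >= 250000 nM for compound 2 as the starting limit, the working expectation is that compound 3 stays high in this assay.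

The expected step is an at least 2.0-fold lower number from compound 2 to compound 3 (0.31 log units; beyond the scatter), a loose estimate towards less compound tolerated. For compound 3 the expected value is 120000 nM, with an estimated range of 25000 nM to 400000 nM.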

Compound 3, half-maximal cytotoxic concentration: > 250000 nM
Compound 3: no number, only a limit; the forecaster's own chance of this, stated with the estimate: 75%; middle value at least 2.0-fold (0.31 log units) away from the limit.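

Compound 3 is reported at > 250000 nM, which is a limit and not a number. Compound 1 and compound 2 also stand only as limits in this assay, so the steps from each of them to compound 3 cannot be read. The compounds shown leave open whether benzoyl, 4-methylbenzyl or hydrogen on the aromatic nitrogen makes any difference to the tolerated concentration.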